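Aryloxyacetate variation at the ester oxygen: compound 4

The compounds below may be only part of what the source reports. "The series", "measured", "known", "first", "only" and "open" are said of these compounds alone.

Measured so far in a functional assay on HCT-116 cells (Homo sapiens) for cytotoxicity, read by sulforhodamine B assay, with a stated time of 72 h; on this read-out lower numbers stand for stronger inhibition and higher numbers for weaker inhibition:
Compound 1 `C=C1C(=O)O[C@@H]2CC(C)=C([C@@H](C)CCCOC(C)=O)[C@@H](OC(=O)CCl)[C@H]12` gives 18800 nM.
Compound 2 `C=C1C(=O)O[C@@H]2CC(C)=C([C@@H](C)CCCOC(C)=O)[C@@H](OC(=O)COc3ccc([N+](=O)[O-])cc3[N+](=O)[O-])[C@H]12` reaches only the assay limit, > 100000 nM, and no number.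
Compound 3 `C=C1C(=O)O[C@@H]2CC(C)=C([C@@H](C)CCCOC(C)=O)[C@@H](OC(=O)COc3cccc4cccnc34)[C@H]12` gives 12100 nM.

Compound 3 holds the lowest of the two numbers; its nearest neighbour is compound 1, and a 1.6-fold lower number from compound 1 to compound 3 (0.19 log units; within the scatter), so the two stand together rather than in any order. For the measured compounds named here, the only step that clears the scatter is an at least 8.2-fold lower number from compound 2 to compound 3 (0.91 log units; beyond the scatter). Compound 2 sits at the limit of > 100000 nM in this assay, at which 1 of the 3 values shown sits.

Compound 4 `C=C1C(=O)O[C@@H]2CC(C)=C([C@@H](C)CCCOC(C)=O)[C@@H](OC(=O)COc3cccc4[nH]nnc34)[C@H]12` differs from compound 3 by a group of 9 heavy atoms (6 carbon, 3 nitrogen; one five-membered aromatic ring with 3 hetero atoms, one six-membered aromatic ring of carbon only) in place of a group of 10 heavy atoms (9 carbon, 1 nitrogen; one six-membered aromatic ring of carbon only, one six-membered aromatic ring with 1 hetero atom), on an oxygen on a saturated carbon. Both measured steps touch this same oxygen. The swap of chloro for the quinolinyloxy group left the number within the scatter, whereas the swap of one aryl group for another moved it by at least a modest amount, so the identity of the aryl group can matter here. The incoming group keeps a fused bicyclic aromatic of similar size, so no step beyond the scatter is expected, and compound 4 is estimated at 16000 nM, between 5000 nM and 50000 nM. This expectation corresponds to a 1.3-fold higher number from compound 3 to compound 4 (0.12 log units; within the scatter).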

Compound 4, half-maximal inhibitory concentration: 23700 nM
For compound 4 the middle estimate is 1.5-fold (0.17 log units) below the measured one; the measured number falls inside the stated range.
By their numbers in this assay, from the lowest: compounds 3, 1 and 4 (each within the scatter of the next). At a limit, above all of these: compound 2.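

In this assay, a second fused bicyclic aryl group on this oxygen gives no separation from the quinolin-8-yl group, a 2.0-fold higher number from compound 3 to compound 4 (0.29 log units; within the scatter), nor from the chloro compound, a 1.3-fold higher number from compound 1 to compound 4 (0.10 log units; within the scatter), so compounds 1, 3 and 4 stand together. The 2,4-dinitrophenyl group now stands apart from two different fused aryl groups rather than one, an at least 4.2-fold lower number from compound 2 to compound 4 (0.62 log units; beyond the scatter). Compound 2 remains a limit and not a number, so that step gives only a bound: the limit of > 100000 nM in this assay, at which 1 of the 4 values shown sits.

On these data alone, whether an unsubstituted phenyl or a mononitrophenyl group on this oxygen would stand with compounds 3 and 4 or with compound 2 remains open. Also open, as far as these compounds go, is how an amine or a carboxylic acid in place of the aryloxy group would read on this chain.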